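Phenyl in place of 2-methylprop-1-en-1-yl: compound 4 expected

The source may hold more compounds than are shown below. What is called first, only, known or untested is meant among the compounds shown, and "the series" means these compounds.

Of the compounds shown here, three sharing one core have been measured in a functional assay on J774.A1 cells (Mus musculus) for inhibition, read by immunoassay, with a stated time of 12 h, tested at 30 uM; on this read-out higher numbers stand for more inhibition at the one concentration tested (going by the name of the read-out) and lower numbers for less inhibition. Compound 1 `CC(C)COc1ccccc1C1CC(=O)c2ccccc2O1` gives 33.5%, compound 2 `CCCCCOc1ccccc1C1CC(=O)c2ccccc2O1` gives 40.1%, and compound 3 `CC(C)=CCOc1ccccc1C1CC(=O)c2ccccc2O1` gives 40.3%, the highest of the three numbers, though its gaps to both others stay within the scatter. Compound 4 `O=C1CC(c2ccccc2OCc2ccccc2)Oc2ccccc21` differs from compound 3 in one place: phenyl in place of 2-methylprop-1-en-1-yl on a saturated chain carbon bound to an oxygen on an aromatic ring. Within the data shown here, two measured steps bear on that same place, a number 6.8 percentage points higher from compound 1 to compound 3 (within the scatter) and a number 0.2 percentage points higher from compound 2 to compound 3 (within the scatter), and neither reaches beyond the scatter. The step to compound 4 is therefore expected to stay within the scatter as well, as a number 2.3 percentage points lower from compound 3 to compound 4 (within the scatter). Compound 4 is estimated in this assay at 38%, with a range from 24% to 52%.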

Compound 4, a percentage reported as inhibition, at one concentration (the size of the read-out at that concentration, not a potency): 91.5%
Estimate against measurement, compound 4: 53.5 percentage points below; measured number above the stated range.
By their numbers in this assay, from the lowest: compounds 1, 2 and 3 (each within the scatter of the next); then compound 4.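

In this assay, the place on a saturated chain carbon bound to an oxygen on an aromatic ring turns out to be far from indifferent: phenyl gives a number 51.2 percentage points higher from compound 3 to compound 4 (beyond the scatter) and a number 51.4 percentage points higher from compound 2 to compound 4 (beyond the scatter) and a number 58 percentage points higher from compound 1 to compound 4 (beyond the scatter), all large, whereas isopropyl, butyl and 2-methylprop-1-en-1-yl had stayed within the scatter of one another. Of the four groups, only phenyl brings a ring. Nothing available explains this jump.

The compounds shown leave open whether any ring would do, such as cyclohexyl or pyridyl. They also leave open how a phenyl ring carrying a carboxylic acid or an amine would read here.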